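The compounds below may be only part of what the source reports. "The series", "measured", "known", "first", "only" and "open" are said of these compounds alone.

Measured compounds:
- compound 1, `COc1cc(N2C(N)=C(C#N)C(c3ccccc3O)C3=C2CC(C)(C)CC3=O)cc(OC)c1OC`: 0% in a functional assay on Ehrlich cells (Mus musculus) for cytotoxicity, tested at 10 ug/mL; a lower number here means a weaker effect, a higher number a stronger effect of the compound at the concentration tested
- compound 2, `COc1cc(N2C(N)=C(C#N)C(c3ccc(Cl)cc3Cl)C3=C2CC(C)(C)CC3=O)cc(OC)c1OC`: 20% in this assay
- compound 3, `COc1cc(N2C(N)=C(C#N)C(c3cccc([N+](=O)[O-])c3)C3=C2CC(C)(C)CC3=O)cc(OC)c1OC`: 5% in this assay

Compound 3 holds the second highest of the three numbers. Its nearest neighbour is compound 1, as a number 5 percentage points higher from compound 1 to compound 3 (within the scatter) shows, a gap within the scatter; compound 2 sits further off, with a number 15 percentage points lower from compound 2 to compound 3 (beyond the scatter). Compound 4, `COc1cc(N2C(N)=C(C#N)C(c3ccccc3)C3=C2CC(C)(C)CC3=O)cc(OC)c1OC`, differs from compound 3 in one place: hydrogen in place of nitro on an aromatic carbon. Among the measured compounds shown here, no measured step removes a nitro group for a hydrogen; the three steps seen, a number 20 percentage points higher from compound 1 to compound 2 (beyond the scatter), a number 5 percentage points higher from compound 1 to compound 3 (within the scatter) and a number 15 percentage points lower from compound 2 to compound 3 (beyond the scatter), all exchange one substituted phenyl for another and are modest at most. The expected step is therefore no change at the digits printed from compound 3 to compound 4 (within the scatter), nothing beyond the scatter. Compound 4 is estimated at 5%, between 0% and 20%.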

Compound 4, a percentage reported as activity, at one concentration (the size of the read-out at that concentration, not a potency): 0%
Compound 4: the middle estimate sits 5 percentage points above what was measured, within the range that was stated.
By their numbers in this assay, from the lowest: compounds 1, 4 and 3 (each within the scatter of the next); then compound 2.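

In this assay, plain phenyl shows that neither the nitro group nor the hydroxy group counts for much on this aromatic ring: losing the nitro gives a step within the scatter (a number 5 percentage points lower from compound 3 to compound 4 (within the scatter)), and so does losing the hydroxy (no change at the digits printed from compound 1 to compound 4 (within the scatter)). Only the 2,4-dichlorophenyl stands apart from phenyl, by a modest step beyond the scatter (a number 20 percentage points lower from compound 2 to compound 4 (beyond the scatter)). Nothing available explains that difference.

Open, going by these compounds, is whether a single chlorine carries that step, and whether an amine or a carboxylic acid on this ring would shift the read-out beyond the scatter.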